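This account rests on a few compounds, and the source may have more. Where it says the series, first, only, none or still open, it means among the compounds named here.

Of the compounds shown here, three have been measured in a functional assay on the whole organism (strain albino) for inhibition, with Rattus norvegicus as the target, read by paw edema, with stated times of 30 min and 5 h, at a dose of 0.28 mmol/kg by the oral route; on this read-out higher numbers stand for more inhibition at the one dose given (going by the name of the read-out) and lower numbers for less inhibition. Compound 1 `COc1ccc(-c2nnc(SCC(=O)Nc3ccc(/C(C)=N/O)cc3)n2-c2ccccc2)cc1` gives 58% in this assay. Compound 2 `COc1ccc(-c2nnc(SCC(=O)Nc3ccc(/C(C)=N/O)cc3)n2-c2ccccc2)cc1OC` gives 76% in this assay, and compound 3 `C=CCn1c(SCC(=O)Nc2ccc(/C(C)=N/O)cc2)nnc1-c1ccc(OC)c(OC)c1` gives 79% in this assay. Compound 2 and compound 1 differ by hydrogen in place of methoxy on an aromatic carbon, and in this assay this change made a number 18 percentage points lower from compound 2 to compound 1 (beyond the scatter). Compound 2 and compound 3 differ in their cores by allyl in place of phenyl on an aromatic nitrogen, and in this assay that exchange made a number 3 percentage points higher from compound 2 to compound 3 (within the scatter), so the two cores carry the same 3,4-dimethoxyphenyl group to about the same effect.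

Compound 4 `C=CCn1c(SCC(=O)Nc2ccc(/C(C)=N/O)cc2)nnc1-c1ccc(OC)cc1` has not yet been measured in this assay. It differs from compound 3 by hydrogen in place of methoxy on an aromatic carbon. This is the same change that separates compound 2 from compound 1, made on the core of compound 3 rather than on the core of compound 2, and the surroundings of the changed carbon are described in the same words for both pairs. Within the data shown here, the expectation for compound 4 therefore rests on the one earlier example of this change, the step of a number 18 percentage points lower from compound 2 to compound 1 (beyond the scatter), applied to the value of compound 3, 79%. On that basis compound 4 is expected to show a step of a number 18 percentage points lower from compound 3 to compound 4 (beyond the scatter) in this assay. Compound 4 is thus estimated at 61% in this assay, with a likely range from 48% to 74%.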

Compound 4, a percentage reported as inhibition, in the whole organism at one dose (the size of the read-out at that dose, not a potency): 72%
The estimate for compound 4 lay 11 percentage points below the measured number, and the stated range covers the measured number.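

In this assay, among these compounds, the replacement of one methoxy by hydrogen, which turns 3,4-dimethoxyphenyl into 4-methoxyphenyl, gave a number 7 percentage points lower from compound 3 to compound 4 (within the scatter), and this step does not stand apart from the earlier one on the other core: the same change on two cores in this assay, a number 18 percentage points lower (beyond the scatter) from compound 2 to compound 1 and a number 7 percentage points lower (within the scatter) from compound 3 to compound 4, 11 percentage points apart, within the scatter of two such steps The exchange of phenyl for allyl on the aromatic nitrogen, read between the two 4-methoxyphenyl compounds, gave a number 14 percentage points higher from compound 1 to compound 4 (beyond the scatter), and it likewise agrees with its earlier counterpart: the same change on two cores in this assay, a number 3 percentage points higher (within the scatter) from compound 2 to compound 3 and a number 14 percentage points higher (beyond the scatter) from compound 1 to compound 4, 11 percentage points apart, within the scatter of two such steps These four compounds therefore give no sign that either change depends on the core, but with only two steps per change, one beyond the scatter and one within it, they do not show that the size of a step carries over, and they cannot fix a single size for either change.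

The compounds shown leave open how a hydroxyl group or a chlorine atom in place of the methoxy would read on either core, and whether a propyl or benzyl group on the aromatic nitrogen would match allyl and phenyl. They also leave open the role of the oxime and the amide, which stay the same in all four compounds.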